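Epimer pair at the assay ceiling: compound 3 to compound 4

The source may hold more compounds than are shown below. What is called first, only, known or untested is meant among the compounds shown, and "the series" means these compounds.

Compound 3 `CCO[C@@]1(CC)CCC2(CO1)[C@@H]1CCC3=C4[C@H](CC3=O)[C@H](C(=O)OC)C[C@@]42CN(C)C1` stands in a functional assay on A549 cells (Homo sapiens) for cytotoxicity, read by MTT assay, with a stated time of 48 h (on this read-out lower numbers stand for stronger inhibition and higher numbers for weaker inhibition), at a limit of the assay, not a number: compound 3 gives > 40000 nM. Compound 1 `CCOC(=O)[C@@H]1C[C@@]23CN(C)C[C@@H](CCC4=C2[C@@H]1CC4=O)C31CC[C@](CC)(OC)OC1` gives > 40000 nM, a limit. Compound 2 `CCOC(=O)[C@@H]1C[C@@]23CN(C)C[C@@H](CCC4=C2[C@H]1CC4=O)C31CC[C@](CC)(OC)OC1` gives > 40000 nM, also a limit. The change to compound 4 `CCO[C@@]1(CC)CCC2(CO1)[C@@H]1CCC3=C4[C@@H](CC3=O)[C@H](C(=O)OC)C[C@@]42CN(C)C1` is the two compounds have the same atoms and bonds; at least one stereo element is drawn with a configuration in one of them and without one in the other: 1 of 6 stereo elements differ; a stereocentre at a saturated ring carbon is drawn R in compound 3 and S in compound 4. For the measured compounds named here, the one measured step of the same kind, a step that the two limits leave unreadable from compound 1 to compound 2, is the only one bearing on it, and its size cannot be read because the limit of > 40000 nM in this assay, at which 3 of the 3 values shown sit, holds both of its ends; the pairing itself rests on (the fact that one of compounds 1 and 2 is drawn with a defined configuration and the other without, at the place where they differ). No step beyond the scatter can therefore be expected in this assay, only another limit. Compound 4 is expected at 60000 nM, within 20000 nM to 200000 nM, the expected step being a step that the limit leaves unreadable from compound 3 to compound 4.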

Compound 4, half-maximal inhibitory concentration: > 40000 nM
Compound 4 ended at the assay's limit; the forecaster's own chance of this, stated with the estimate: 85%; the middle value does not contradict the limit.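

In this assay, no step can be read between compound 3 and compound 4: both values are limits of the assay, not numbers. The compounds shown leave open whether the configuration at this stereocentre affects cytotoxicity at all.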